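Working notes: paw edema inhibition, compound 2 to compound 3

The source may report more compounds than this note shows. Statements on the series, on what has been measured and on what is new or still open speak of the compounds shown alone.

Measured so far:
compound 1 `CCOC(=O)c1c(-c2ccc(Cl)cc2)cc(-c2ccccc2)nc1Nc1ccc(C)cc1` gives 90.9% in a functional assay on the whole organism (strain Wister albino) for inhibition, with Rattus norvegicus as the target, read by paw edema, with stated times of 1 h and 4 h, at a dose of 50 mg/kg by the intraperitoneal route; on this read-out higher numbers stand for more inhibition at the one dose given (going by the name of the read-out) and lower numbers for less inhibition
compound 2 `CCOC(=O)c1c(-c2ccc(Cl)cc2)cc(-c2ccccc2)nc1Nc1ccc(OC)cc1` gives 57.2% in this assay

On the numbers shown, compound 2 stands lowest of the two. Within the data shown here, the only measured step leads to it: a number 33.7 percentage points lower from compound 1 to compound 2 (beyond the scatter). Nothing else in the series speaks to the effect of a group at this place.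

Compound 3 `CCOC(=O)c1c(-c2ccc(Cl)cc2)cc(-c2ccccc2)nc1Nc1ccc(Cl)cc1` is not yet measured in this assay. It differs from compound 2 by the following change: chloro in place of methoxy on an aromatic carbon. Among the measured compounds shown here, the one step that bears on it shows that exchanging the group at this place can move the read-out by a large amount, but it compares methyl with methoxy, not chloro with either, so its direction for compound 3 is not fixed by the data. Given that compound 1 with methyl reaches 90.9% and compound 2 with methoxy only 57.2%, a number somewhere between the two is expected for compound 3, with a wide range. The estimate for compound 3 is 72%, between 45% and 95%, which means an expected step of a number 14.8 percentage points higher from compound 2 to compound 3 (beyond the scatter).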

Compound 3, a percentage reported as inhibition, in the whole organism at one dose (the size of the read-out at that dose, not a potency): 95.9%
Beside the measured number, compound 3's estimate is 23.9 percentage points below it; measured number outside the range, above it.
By their numbers in this assay, from the lowest: compound 2; then compounds 1 and 3 (each within the scatter of the next).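

Exchanging methoxy for chloro on the aromatic carbon in this assay gives a number 38.7 percentage points higher from compound 2 to compound 3 (beyond the scatter), a large step in the opposite direction to a number 33.7 percentage points lower from compound 1 to compound 2 (beyond the scatter), so the low reading at this place is not shared by every replacement of methyl. Chloro in place of methyl gives a number 5 percentage points higher from compound 1 to compound 3 (within the scatter), which means that methyl and chloro cannot be told apart here, and among the three groups shown, only methoxy, in compound 2, stands apart. Nothing measured in this set of compounds accounts for that difference between methoxy and the other two groups.

On these data alone, whether the low reading belongs to methoxy alone or also appears with other groups at this place, such as hydroxy, an amine or a longer ether chain, stays open, as does whether fluoro or bromo would read like chloro. As far as these compounds go, the ethyl ester and the rest of the core are the same in all three compounds, so it is also open whether the same order of groups would hold with a carboxylic acid in place of that ester.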